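A Six-Membered Sugar in Place of a Five-Membered One

This account rests on a few compounds, and the source may have more. Where it says the series, first, only, none or still open, it means among the compounds named here.

Of the compounds shown here, three built on one shared core have been tested in a toxicity assay on L02 cells (Homo sapiens) for cytotoxicity, read by MTT assay, with a stated time of 72 h; a lower number here means a stronger inhibitor, a higher number a weaker inhibitor. Compound 1 `O=C1c2c[n+]([O-])c3ccccc3c2C(=O)c2c1c1ccccc1n2Cc1cn([C@H]2O[C@H](CO)[C@@H](O)[C@H]2O)nn1` gives 950 nM. Compound 2 `O=C1c2c[n+]([O-])c3ccccc3c2C(=O)c2c1c1ccccc1n2CCCCN1CCNCC1` gives 1380 nM, and compound 3 `O=C1c2c[n+]([O-])c3ccccc3c2C(=O)c2c1c1ccccc1n2CCCCN1CCCCC1` gives 610 nM; compound 1 sits between these two, and both gaps lie within the usual scatter. Among the compounds with values here, the only step between measured compounds, a 2.3-fold lower number from compound 2 to compound 3 (0.35 log units; beyond the scatter), concerns the end of a chain and says nothing about the sugar. Compound 4 `O=C1c2c[n+]([O-])c3ccccc3c2C(=O)c2c1c1ccccc1n2Cc1cn([C@@H]2O[C@H](CO)[C@@H](O)[C@H](O)[C@H]2O)nn1` differs from compound 1 by 3,4,5-trihydroxy-6-(hydroxymethyl)oxan-2-yl in place of 3,4-dihydroxy-5-(hydroxymethyl)oxolan-2-yl on an aromatic nitrogen. Within the data shown here, no measured step bears on this change, so a number close to that of compound 1 is expected. The estimate for compound 4 is 1000 nM, within 500 nM to 2000 nM, and the expected step of a 1.1-fold higher number from compound 1 to compound 4 (0.02 log units; within the scatter) stays within the scatter.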

Compound 4, half-maximal inhibitory concentration: 420 nM
The estimate for compound 4 lay 2.4-fold (0.38 log units) above the measured number; the measured number lies below the stated range.
By their numbers in this assay, from the lowest: compounds 4, 3, 1 and 2 (each within the scatter of the next, the first and the last beyond it).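

Until now, nothing showed whether the group on this aromatic nitrogen could shift the number in this assay. Replacing the five-membered sugar with the six-membered one gives a 2.3-fold lower number from compound 1 to compound 4 (0.35 log units; beyond the scatter) and so shows that this position responds to the sugar it carries, though modestly. No measurement here explains this step. The six-membered sugar differs in both ring size and its added carbon and oxygen atoms, so the compounds shown cannot separate these changes. On these data alone, an amine or carboxylic acid on the sugar, or a longer chain before the sugar, also remains open.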